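The compounds below may be only part of what the source reports. "The series", "measured", "known", "first", "only" and "open" are said of these compounds alone.

Compound 1 `c1cncc(N2CC[C@@H]3CN[C@@H]3C2)c1` and compound 3 `c1cncc(N2C[C@@H]3CCNC[C@@H]32)c1` share the same atoms joined differently; how their two cores differ is not broken down here. In a functional assay on HEK293 cells for agonist activity at Neuronal acetylcholine receptor; alpha4/beta2 (Homo sapiens), read by FLIPR (on this read-out lower numbers stand for an effect already at smaller amounts and higher numbers for an effect only at larger amounts of compound), compound 1 gives 330 nM, and compound 3 gives 410 nM, the two values lying within the usual scatter of each other. Compound 2 `Clc1ccc(N2CC[C@@H]3CN[C@@H]3C2)cn1` carries chloro in place of hydrogen on an aromatic carbon relative to compound 1, and in this assay compound 2 gives 24 nM, a step of a 14-fold lower number from compound 1 to compound 2 (1.14 log units; beyond the scatter). Compound 4 `Clc1ccc(N2C[C@@H]3CCNC[C@@H]32)cn1` carries the same change on the core of compound 3: chloro in place of hydrogen on an aromatic carbon. Because the same change gave a 14-fold lower number from compound 1 to compound 2 (1.14 log units; beyond the scatter), compound 4 is expected to show a step of about a 14-fold lower number from compound 3 to compound 4 (1.14 log units; beyond the scatter) in this assay. On this basis compound 4 is estimated at 30 nM, with a likely range from 12 nM to 80 nM.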

Compound 4, half-maximal effective concentration: 37.4 nM
For compound 4 the middle estimate is 1.2-fold (0.10 log units) below the measured one, within the range that was stated.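

In this assay, chloro in place of hydrogen on an aromatic carbon gives an 11-fold lower number from compound 3 to compound 4 (1.04 log units; beyond the scatter) on the second core, so the large gain seen on the first core carries over. The two steps agree in size: the same change on two cores in this assay, a 14-fold lower number (1.14 log units; beyond the scatter) from compound 1 to compound 2 and an 11-fold lower number (1.04 log units; beyond the scatter) from compound 3 to compound 4, 1.3-fold (0.10 log units) apart, within the scatter of two such steps. This shows that the change transfers between these two cores with its size kept, but it rests on a single change and a single pair of cores, so it shows neither that the step would hold on any other core nor why it arises.

The compounds shown leave open whether bromo, methyl, nitrile or an amine at the same place would also give matching steps on both cores. They also leave open how either core would respond to a substituent elsewhere on the aromatic ring.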